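The compounds below may be only part of what the source reports. "The series", "measured", "known", "first", "only" and "open" are said of these compounds alone.

Compound 1 `Nc1nc(-c2cccs2)nc2cn(-c3ccccc3)nc12`: 9.7 nM
Compound 2 `COc1ccc(-c2nc(N)c3nn(-c4ccccc4)cc3n2)cc1`: 33 nM
Compound 3 `COc1ccc(C(=O)Nc2nc(-c3ccc(OC)cc3)nc3cn(-c4ccccc4)nc23)cc1`: 1.31 nM

All three were measured in an assay on CHO cells for displacement of a labelled ligand from adenosine receptor A3 (Homo sapiens), read by scintillation counting, with a stated time of 60 min; a higher number here means a weaker inhibitor, a lower number a stronger inhibitor. Compound 2 stands highest of the three numbers; its nearest neighbour is compound 1, reached by a 3.4-fold higher number from compound 1 to compound 2 (0.53 log units; beyond the scatter), and its furthest is compound 3, reached by a 25-fold lower number from compound 2 to compound 3 (1.40 log units; beyond the scatter). Compound 4 `Nc1nc(-c2ccc(O)cc2)nc2cn(-c3ccccc3)nc12` differs from compound 2 only at the oxygen: hydrogen in place of methyl on an oxygen on an aromatic ring. Neither measured step bears on this spot. The step from compound 1 to compound 2 exchanges the whole aryl group, and the step from compound 2 to compound 3 adds a carbonyl-bearing group on a ring nitrogen. With no comparison of this kind available, the expectation is a change within the scatter. Compound 4 is therefore estimated at 40 nM, ranging from 15 nM to 110 nM. That corresponds to an expected 1.2-fold higher number from compound 2 to compound 4 (0.08 log units; within the scatter).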

Compound 4, inhibition constant: 432 nM
Compound 4: middle estimate off by 11-fold (1.03 log units), on the low side, and the stated range ends below it.
By their numbers in this assay, from the lowest: compound 3; then compound 1; then compound 2; then compound 4.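

Compounds 1 to 3 changed a whole aryl group or a ring nitrogen, whereas this pair changes only the end of the oxygen, and that small exchange gives a 13-fold higher number from compound 2 to compound 4 (1.12 log units; beyond the scatter) on its own. A single methyl at this spot therefore counts for a great deal. With the hydroxy group the comparison with thiophen-2-yl reads a 45-fold higher number from compound 1 to compound 4 (1.65 log units; beyond the scatter) and so lies much further out than a 3.4-fold higher number from compound 1 to compound 2 (0.53 log units; beyond the scatter) for the methoxy group. Nothing available explains why the hydrogen costs so much.

On these data alone, how an ethoxy group or an amine would read in place of the methoxy stays open. So does whether the same exchange would cost as much in compound 3, which carries the (4-methoxyphenyl)carbonyl group.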